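Hybrid series: fluorouracil units on a lactone core

A few compounds are considered here, and "the series" means these few. Any claim that something is new, unique, unknown or untested is made for them only; others in the source may bear on it.

Measured compounds:
- compound 1, `C=C1C(=O)O[C@H]2[C@H]1CC/C(COC(=O)Cn1cc(F)c(=O)[nH]c1=O)=C\CC[C@@]1(C)O[C@@H]21`: > 20000 nM
- compound 2, `C=C1C(=O)O[C@H]2[C@H]1CC/C(COC(=O)CCC(=O)N1CCN(C(=O)Cn3cc(F)c(=O)n(Cc4ccccc4)c3=O)CC1)=C\CC[C@@]1(C)O[C@@H]21`: > 20000 nM

In a functional assay on Bel-7402 cells (Homo sapiens) for antiproliferative activity, read by MTT assay, with a stated time of 72 h (on this read-out higher numbers stand for weaker inhibition and lower numbers for stronger inhibition), compound 1 reaches only the assay limit, > 20000 nM. Compound 2 likewise gives only a limit in this assay, > 20000 nM. For the measured compounds named here, both values shown thus sit at the limit (the limit of > 20000 nM in this assay, at which 2 of the 2 values shown sit), and no measured step exists. Compound 3, `C=C1C(=O)O[C@H]2[C@H]1CC/C(COC(=O)Cn1cc(F)c(=O)n(Cc3ccc(Cl)cc3)c1=O)=C\CC[C@@]1(C)O[C@@H]21`, differs from compound 1 in one place: 4-chlorobenzyl in place of hydrogen on an aromatic nitrogen. With nothing measured beyond the limit, no direction can be read from the data. Compound 3 is expected to stay weak, with the step of a number no higher from compound 1 to compound 3 (the limit leaves the size open) likely within the scatter. The estimate for compound 3 in this assay is 20000 nM, ranging from 5000 nM to 60000 nM.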

Compound 3, half-maximal inhibitory concentration: 2560 nM
Beside the measured number, compound 3's estimate is 7.8-fold (0.89 log units) above it, outside the stated range (below it).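

In this assay, 4-chlorobenzyl in place of hydrogen on an aromatic nitrogen gives an at least 7.8-fold lower number from compound 1 to compound 3 (0.89 log units; beyond the scatter). This ring nitrogen is therefore a position where a change on the shared core can bring a value clear of the limit, which neither earlier compound showed. Compound 1 gives only a limit, so the step has a floor and no exact size: the limit of > 20000 nM in this assay, at which 2 of the 3 values shown sit.

The compounds shown leave open whether the chlorine or the benzyl carries the step, which an unsubstituted benzyl or a methyl on the same nitrogen would separate.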